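This account rests on a few compounds, and the source may have more. Where it says the series, first, only, none or still open, it means among the compounds named here.

Measured in an ADME assay on J774 cells (Mus musculus) for antiproliferative activity, with a stated time of 72 h; a lower number here means that less compound is needed, a higher number that more compound is needed for the effect:

- Compound 1 `CCCCc1cc2c(=O)cc(C)[nH]c2cc1OCCOc1ccccc1`: 28000 nM
- Compound 2 `CCc1c(C)[nH]c2cc(OCCOc3ccccc3)c(Cl)cc2c1=O`: > 28000 nM, a limit of the assay
- Compound 3 `CCc1c(C)[nH]c2cc(OCCOc3ccccc3)c(Br)cc2c1=O`: > 25000 nM, a limit of the assay

Within the data shown here, compound 1 stands alone on the numbers so far, with 28000 nM as the only true value in this assay. The other two entries are limits, so the series has no numerical ranking.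

Compound 4 `CCCCc1cc2c(=O)c(-c3cccnc3)c(C)[nH]c2cc1OCCOc1ccccc1` follows from compound 1 through a single change: pyridin-3-yl in place of hydrogen on an aromatic carbon. Among the measured compounds shown here, the only measured step is a step that the two limits leave unreadable from compound 2 to compound 3. For the measured compounds named here, it concerns a different change and gives no size to carry over, so no measured step shows what a substituent at this carbon does. The expectation therefore rests on compound 1 at 28000 nM, and no step beyond the scatter is the default. On these data alone, the range stays wide and leans towards lower numbers, since the new group is untested here. The estimated step is a 1.6-fold lower number from compound 1 to compound 4 (0.19 log units; within the scatter). A limit rather than a number is also a likely outcome for the next measurement. For compound 4 the expected value is 18000 nM, with an estimated range of 5000 nM to 40000 nM.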

Compound 4, half-maximal effective concentration: 23000 nM
The estimate for compound 4 lay 1.3-fold (0.11 log units) below the measured number, within the range that was stated.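

At the aromatic carbon ortho to a methyl group and two atoms from the ring nitrogen, a 1.2-fold lower number from compound 1 to compound 4 (0.09 log units; within the scatter) is the step for pyridin-3-yl in place of hydrogen in this assay, the first measured substituent at this carbon. The series therefore gains a pair that differs in one place and has true numbers at both ends, and at this carbon the data do not separate hydrogen from a six-membered aromatic ring with 1 hetero atom. No measured property in the data bears on the size of this step.

On these data alone, whether an amine, a carboxylic acid, a phenyl ring or a longer chain at this carbon would give a step beyond the scatter remains open, as does the role of the ring nitrogen in pyridin-3-yl. Compound 2 and compound 3 each carry only a limit, the step between them cannot be read, and the effect of bromo in place of chloro on an aromatic carbon remains unresolved.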